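Swapping a Sulfur-Linked Benzyl Group for a Butylamino Chain

The compounds below may be only part of what the source reports. "The series", "measured", "known", "first", "only" and "open" are said of these compounds alone.

Measured so far:
compound 1, `CCCCOc1nc(N)c2[nH]c(=O)n(Cc3ccccc3)c2n1`: 0.1 mg/kg
compound 2, `Nc1nc(SCc2ccccc2)nc2c1nc(O)n2Cc1ccccc1`: > 1 mg/kg
compound 3, `Nc1ncnc2c1nc(O)n2Cc1ccc(F)cc1`: 30 mg/kg

Of the compounds shown here, three have been tested in a functional assay on the whole organism for activation, with Mus musculus as the target; a higher number here means that more compound is needed for the effect, a lower number that less compound is needed. Compound 1 needs 0.1 mg/kg to produce the effect. Compound 3 needs 30 mg/kg. For compound 2 the assay reports only a limit, > 1 mg/kg, so the dose it needs is not known as a number; the line the limit of > 1 mg/kg in this assay, at which 1 of the 3 values shown sits, marks where it sits among the three readings.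

Compound 4, `CCCCNc1nc(N)c2nc(O)n(Cc3ccccc3)c2n1`, has not yet been measured. It differs from compound 2 in a single spot: butylamino in place of benzylsulfanyl on an aromatic carbon. The new group stands on an aromatic carbon of a six-membered aromatic ring with two nitrogen atoms, part of a fused system of two rings, between two ring nitrogen atoms.

Among the measured compounds shown here, no step between measured compounds is available, so the size of this change can only be expected, not read off. Compound 1 gives 0.1 mg/kg in this assay, and compound 4 is nearer in build to compound 1 than compound 2 is. A drop in the needed dose relative to compound 2, beyond the usual scatter, is therefore expected. Compound 4 is expected at 0.5 mg/kg, between 0.1 mg/kg and 3 mg/kg, an expected step of an at least 2.0-fold lower number from compound 2 to compound 4 (0.30 log units; that floor lies within the scatter).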

Compound 4, minimum effective dose: 0.1 mg/kg
For compound 4 the middle estimate is 5.0-fold (0.70 log units) above the measured one; the measured number falls inside the stated range.
By their numbers in this assay, from the lowest: compounds 1 and 4 (each within the scatter of the next); then compound 3.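

In this assay, putting butylamino in place of benzylsulfanyl on this aromatic carbon gives an at least 10-fold lower number from compound 2 to compound 4 (1.00 log units; beyond the scatter). Among the compounds shown here, this is the first direct comparison of two compounds that differ in one place, and it shows that the group here need not carry a six-membered aromatic ring of carbon only for a low dose to suffice: compound 4 gives 0.1 mg/kg, within the usual scatter of compound 1, which has a butoxy group on the same carbon. On these data alone, the true size of the step remains unknown, and the reading for compound 2 is only a limit: the limit of > 1 mg/kg in this assay, at which 1 of the 4 values shown sits.

The change removes the ring, shortens the group and replaces sulfur with nitrogen as the atom attached to the core, and the compounds shown leave open which of these differences accounts for the step. A benzylamino group would keep the ring with the nitrogen attachment, while a propylamino group or a longer hexylamino chain would show how far the dose depends on chain length at this position.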